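Amide substituent step from compound 3 to compound 4

The compounds below may be only part of what the source reports. "The series", "measured", "known", "first", "only" and "open" are said of these compounds alone.

Measured in an in vitro ADME assay on microsomes from liver (Mus musculus) for pharmacokinetics, read by LC-MS, with a stated time of 10 min, tested at 1 uM; on this read-out higher numbers stand for fast clearance and lower numbers for slow clearance:
- compound 1 `CN1C[C@H](C(=O)Nc2ccc(C3CC3)cc2)[C@@H](c2ccc(/C=C/C(=O)Nc3ccccc3N)cc2)C1` gives 60 mL/min/kg
- compound 2 `Cc1cc(NC(=O)[C@H]2CN(C)C[C@@H]2c2ccc(/C=C/C(=O)Nc3ccccc3N)cc2)ccc1Cl` gives 65 mL/min/kg
- compound 3 `CN1C[C@H](C(=O)Nc2ccc(Cl)cc2F)[C@@H](c2ccc(/C=C/C(=O)Nc3ccccc3N)cc2)C1` gives 43 mL/min/kg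

Compound 3 stands level with the other two measured compounds, within the scatter of each. The steps that reach it are a 1.4-fold lower number from compound 1 to compound 3 (0.14 log units; within the scatter) and a 1.5-fold lower number from compound 2 to compound 3 (0.18 log units; within the scatter). The remaining step, a 1.1-fold higher number from compound 1 to compound 2 (0.03 log units; within the scatter), is no larger.

The next structure is compound 4 `CN1C[C@H](C(=O)Nc2ccccn2)[C@@H](c2ccc(/C=C/C(=O)Nc3ccccc3N)cc2)C1`, still unmeasured. The change is pyridin-2-yl in place of 4-chloro-2-fluorophenyl on an amide-type nitrogen. All three measured steps sit at this same place, so they bear on the change, but each swaps one carbon-only aromatic ring for another. None of them tests a ring with a hetero atom, and the data give no direction for this change. No step beyond the scatter is therefore expected in this assay, though with wide uncertainty. The expected step is a 1.0-fold lower number from compound 3 to compound 4 (0.01 log units; within the scatter). Compound 4 is estimated at 42 mL/min/kg, with an expected range of 22 mL/min/kg to 75 mL/min/kg.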

Compound 4, clearance: 40 mL/min/kg
Compound 4: middle estimate off by 1.1-fold (0.02 log units), on the high side, and the stated range covers the measured number.
By their numbers in this assay, from the lowest: compounds 4, 3, 1 and 2 (each within the scatter of the next).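

In this assay, a ring with a hetero atom on the amide-type nitrogen stays level with all three carbon-only aromatic rings: a 1.1-fold lower number from compound 3 to compound 4 (0.03 log units; within the scatter), a 1.6-fold lower number from compound 2 to compound 4 (0.21 log units; within the scatter) and a 1.5-fold lower number from compound 1 to compound 4 (0.18 log units; within the scatter). This position therefore accepts pyridin-2-yl, with its hydrogen-bond acceptor and without chlorine or fluorine, with no step beyond the scatter on this read-out. No available measurement accounts for this flat result.

The compounds shown hold only six-membered aromatic rings at this nitrogen, and they say nothing about a piperidine ring, a carboxylic acid or a longer alkyl chain there. The change to compound 4 also brings in the ring nitrogen and removes both halogens at once, so plain phenyl remains the group that would separate these changes.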